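Replacing the benzylamine of compound 2 with a benzamide

The source may report more compounds than this note shows. Statements on the series, on what has been measured and on what is new or still open speak of the compounds shown alone.

Measured compounds:
compound 1, `C[C@@H](C(=O)NC1CCCCC1)[C@H]1CC[C@@H](c2ccnc3ccc(F)cc32)CC1`, gives 470 nM in an assay on blood for inhibition of Indoleamine 2,3-dioxygenase 1 (Homo sapiens), read by mass spectrometry, with stated times of 4 h and 18 h; on this read-out higher numbers stand for weaker inhibition and lower numbers for stronger inhibition
compound 2, `C[C@@H](NCc1ccc(Cl)cc1)[C@H]1CC[C@@H](c2ccnc3ccc(F)cc32)CC1`, gives > 1000 nM in this assay
compound 3, `C[C@@H](c1nc2ccc(Cl)cc2[nH]1)[C@H]1CC[C@@H](c2ccnc3ccc(F)cc32)CC1`, gives 28 nM in this assay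

Compound 2 stands at a limit of this assay, not at a number: it sits at the limit of > 1000 nM in this assay, at which 1 of the 3 values shown sits. Compound 4, `C[C@@H](NC(=O)c1ccccc1Cl)[C@H]1CC[C@@H](c2ccnc3ccc(F)cc32)CC1`, differs from compound 2 by (2-chlorophenyl)carbonyl in place of 4-chlorobenzyl on an amine nitrogen. Among the compounds with values here, the one measured step that bears on this change is an at least 2.1-fold higher number from compound 1 to compound 2 (0.32 log units; beyond the scatter), in which a carbonyl next to the nitrogen was given up for a benzyl group and the number rose. Compound 4 brings a carbonyl back onto that nitrogen, so a step downward, toward stronger inhibition, is expected in this assay, its size uncertain since compound 2 is only a limit. Compound 4 is therefore estimated at 400 nM, within 100 nM to 1500 nM. This estimate means a step of an at least 2.5-fold lower number from compound 2 to compound 4 (0.39 log units; beyond the scatter).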

Compound 4, half-maximal inhibitory concentration: 135 nM
Compound 4: the middle estimate sits 3.0-fold (0.47 log units) above what was measured, within the range that was stated.
By their numbers in this assay, from the lowest: compound 3; then compound 4; then compound 1. At a limit, above all of these: compound 2.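

Putting (2-chlorophenyl)carbonyl in place of 4-chlorobenzyl on the amine nitrogen gives an at least 7.4-fold lower number from compound 2 to compound 4 (0.86 log units; beyond the scatter) in this assay, showing that this nitrogen can carry a carbonyl together with a chlorine-bearing aromatic ring. The value of compound 2 is a limit, not a number: the limit of > 1000 nM in this assay, at which 1 of the 4 values shown sits. The change adds the carbonyl and also moves the chlorine, so the step cannot be credited to either alone.

Still open, on these data alone, is whether a (4-chlorophenyl)carbonyl or an unsubstituted benzoyl on this nitrogen would read like compound 4. As far as these compounds go, how a sulfonamide would read there is also open.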